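Methyl groups added to the triazole-borne phenyl

The source may report more compounds than this note shows. Statements on the series, on what has been measured and on what is new or still open speak of the compounds shown alone.

Three measured compounds share one core and differ in the group on the amide nitrogen. Compound 1, `CC(C)n1ncc2c(C(=O)Nc3ccccc3)cccc21`, gives 11900 nM in a functional assay on PC-3 cells (Homo sapiens) for inhibition, read by MTT assay, with a stated time of 72 h; on this read-out lower numbers stand for stronger inhibition and higher numbers for weaker inhibition. Compound 2, `CC(C)n1ncc2c(C(=O)Nc3cccnc3)cccc21`, reaches only a limit of this assay, > 40000 nM. In that pair, pyridin-3-yl in place of phenyl on the amide-type nitrogen produced an at least 3.3-fold higher number from compound 1 to compound 2 (0.52 log units; beyond the scatter). Compound 3, `CC(C)n1ncc2c(C(=O)NCc3cn(-c4ccccc4)nn3)cccc21`, gives 26000 nM in this assay and so holds the higher of the two plain numbers, standing above compound 1 by more than the usual scatter.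

Compound 4, `Cc1ccc(-n2cc(CNC(=O)c3cccc4c3cnn4C(C)C)nn2)cc1C`, carries 3,4-dimethylphenyl in place of phenyl on an aromatic nitrogen. For the measured compounds named here, no measured step touches this position: the single measured change concerns the amide-type nitrogen, not the aromatic nitrogen of the five-membered ring. The one limit seen, (the limit of > 40000 nM in this assay, at which 1 of the 3 values shown sits), belongs to compound 2 alone. With nothing to point either way, the step from compound 3 to compound 4 is expected to be no change at the digits printed from compound 3 to compound 4 (within the scatter), not beyond the scatter. Compound 4 is therefore estimated at 26000 nM, within a range of 10000 nM to 60000 nM.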

Compound 4, half-maximal inhibitory concentration: 23400 nM
Compound 4: middle estimate off by 1.1-fold (0.05 log units), on the high side; measured number inside the range.
By their numbers in this assay, from the lowest: compounds 1, 4 and 3 (each within the scatter of the next, the first and the last beyond it). At a limit, above all of these: compound 2.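

Placing 3,4-dimethylphenyl in place of phenyl on the aromatic nitrogen of the five-membered ring gave a 1.1-fold lower number from compound 3 to compound 4 (0.05 log units; within the scatter) in this assay. For the compounds shown here, this is the only measured change at this position, and it shows that adding these methyl groups leaves the number where repeat measurements could place it, something the earlier compounds, which varied only the group on the amide nitrogen, could not show. Nothing in the data shown bears on why the number stays put.

Going by these compounds alone, one swap gives only a single reading of this position, so it cannot say how far the result extends. A phenyl carrying an amine or a carboxylic acid, or a longer chain such as hexyl in place of the phenyl, might behave quite differently here.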